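Aryl ring swaps on the imidazoline ether core

A few compounds are considered here, and "the series" means these few. Any claim that something is new, unique, unknown or untested is made for them only; others in the source may bear on it.

Compound 3 `Cc1ccoc1-c1ccccc1OCC1=NCCN1` carries 3-methylfuran-2-yl on the shared core. In a functional assay for activation of Alpha-1B adrenergic receptor (Homo sapiens), read by calcium flux (a higher number here means that more compound is needed for the effect, a lower number that less compound is needed), compound 3 gives a limit only, < 100000 nM. Compound 1 `c1ccc(-c2ccncn2)c(OCC2=NCCN2)c1`, with pyrimidin-4-yl in that place, likewise returns a limit in this assay, < 100000 nM. Among the compounds with values here, compound 2 `c1ccc(-c2ccsc2)c(OCC2=NCCN2)c1`, with thiophen-3-yl, is the one member with a number in this assay, 15.9 nM. The step that the limit leaves unreadable from compound 1 to compound 2 and the step that the limit leaves unreadable from compound 2 to compound 3 cannot be sized, and a step that the two limits leave unreadable from compound 1 to compound 3 is equally unreadable; what the series shows is the limit of < 100000 nM in this assay, at which 2 of the 3 values shown sit.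

Compound 4 `Cc1cnsc1-c1ccccc1OCC1=NCCN1` is the next member: 4-methyl-1,2-thiazol-5-yl in place of 3-methylfuran-2-yl on an aromatic carbon. The change keeps the methyl of compound 3, brings in a sulfur as found in compound 2, and carries two hetero atoms as the ring of compound 1 does. The step that bears most on it is a step that the limit leaves unreadable from compound 2 to compound 3, the exchange of a sulfur-containing five-membered ring for an oxygen-containing one, but its size is hidden by the limit. No direction can be expected with confidence in this assay, so a wide estimate is used. Compound 4 is expected at 3000 nM, with a range from 100 nM to 100000 nM. This estimate corresponds to an expected step that the limit leaves unreadable from compound 3 to compound 4.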

Compound 4, half-maximal effective concentration: < 100000 nM
Compound 4 was reported as a limit; the forecaster's own chance of this, stated with the estimate: 40%; the middle value does not contradict the limit.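

In this assay compound 4 gives only a limit, < 100000 nM. No new step can be read between compound 4 and compound 1, compound 2 or compound 3, and the series still shows one recurring limit: the limit of < 100000 nM in this assay, at which 3 of the 4 values shown sit.

The compounds shown leave open how far compound 1, compound 3 and compound 4 actually lie from compound 2.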